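This account rests on a few compounds, and the source may have more. Where it says the series, first, only, none or still open, it means among the compounds named here.

Measured so far:
compound 1 `O=C(CN1CN(c2ccccc2)C2(CCN(C(=O)c3ccc(C4CCCCC4)cc3)CC2)C1=O)N1CCC(CO)CC1` — 1100 nM
compound 2 `CC(C)(C)OC(=O)NC1CCN(C(=O)CN2CN(c3ccccc3)C3(CCN(C(=O)c4ccc(C5CCCCC5)cc4)CC3)C2=O)CC1` — 4800 nM

In an assay on HEK293 cells for displacement of a labelled ligand from NPC1-like intracellular cholesterol transporter 1 (Homo sapiens) (a higher number here means a weaker inhibitor, a lower number a stronger inhibitor), compound 1 gives the lowest number of the two; the nearest is compound 2, separated by a 4.4-fold higher number from compound 1 to compound 2 (0.64 log units; beyond the scatter). Compound 3 `O=C(CN1CN(c2ccccc2)C2(CCN(C(=O)c3ccc(C4CCCCC4)cc3)CC2)C1=O)NCCCCO` is not yet measured. Its change from compound 1 is (4-hydroxybutyl)amino in place of 4-(hydroxymethyl)piperidin-1-yl on a carbonyl carbon. Among the compounds with values here, the only measured step alters the group on a saturated ring carbon, not the ring itself, so nothing measured bears directly on trading the ring for a chain; it shows only that change at this end of the molecule cost a modest step. Expected is a 1.5-fold higher number from compound 1 to compound 3 (0.16 log units; within the scatter), within the scatter or a modest weakening. Compound 3 is estimated at 1600 nM, range 600 nM to 4500 nM.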

Compound 3, half-maximal inhibitory concentration: 10300 nM
Compound 3: middle estimate off by 6.4-fold (0.81 log units), on the low side; measured number outside the range, above it.
By their numbers in this assay, from the lowest: compound 1; then compound 2; then compound 3.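

In this assay, replacing the 4-(hydroxymethyl)piperidin-1-yl ring with the open (4-hydroxybutyl)amino chain on this carbonyl carbon gives a 9.4-fold higher number from compound 1 to compound 3 (0.97 log units; beyond the scatter), so keeping a terminal hydroxyl is not enough to hold the number here. The ring itself therefore counts at this position, not only the group on its saturated ring carbon, although loss of the ring and gain of the amide hydrogen come together in this one step. No supporting measurement bears on why the number rises.

Open, going by these compounds, is whether an N-methyl amide carrying the same 4-hydroxybutyl chain, which has no amide hydrogen, would return to the level of compound 1. Also open, on these data alone, is how a piperidine ring bearing a carboxylic acid or an amine would read.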